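Adding a Chloro Group: Expected Cytotoxicity of Compound 3

The source may hold more compounds than are shown below. What is called first, only, known or untested is meant among the compounds shown, and "the series" means these compounds.

Compound 1 `O=C(Nc1cccc(-c2nc3ccccc3s2)c1)c1cc([N+](=O)[O-])ccc1Cl` and compound 2 `O=C(Nc1cccc(-c2nc3ccccc3o2)c1)c1cc([N+](=O)[O-])ccc1Cl` share one core and differ at a single position. In an ADME assay on HepG2 cells (Homo sapiens) for cytotoxicity, with a stated time of 72 h (on this read-out lower numbers stand for an effect already at smaller amounts and higher numbers for an effect only at larger amounts of compound), compound 1 gives > 27000 nM, which is a limit of the assay rather than a number. Compound 2 likewise reaches only a limit in this assay, > 25000 nM. The step that the two limits leave unreadable from compound 1 to compound 2 is therefore unreadable because the limit of > 27000 nM in this assay, at which 1 of the 2 values shown sits, and the limit of > 25000 nM in this assay, at which 1 of the 2 values shown sits, are both limits, not measured numbers.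

Compound 3 `O=C(Nc1cc(-c2nc3ccccc3s2)ccc1Cl)c1cc([N+](=O)[O-])ccc1Cl` is compound 1 with one change: chloro in place of hydrogen on an aromatic carbon. Going by the values given here, no measured step bears on this change, and the single step available gives no direction or size to build on. The step that the limit leaves unreadable from compound 1 to compound 3 is expected to be none beyond the scatter, since both measured compounds sit at limits. Compound 3 is estimated at 30000 nM, within 10000 nM to 90000 nM, and most likely reported again as a limit.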

Compound 3, half-maximal effective concentration: > 25000 nM
Compound 3 was reported as a limit; the forecaster's own chance of this, stated with the estimate: 70%; the middle value is on the limit's open side.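

Compound 1 and compound 3 both stand at limits in this assay, not at measured numbers, and no step can be read between them. The compounds shown leave open whether chloro in place of hydrogen on an aromatic carbon changes the concentration needed for cytotoxicity at all.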